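Cyclopentyl for phenyl at the cytotoxicity limit

A few compounds are considered here, and "the series" means these few. Any claim that something is new, unique, unknown or untested is made for them only; others in the source may bear on it.

In an ADME assay on Huh-7 cells (Homo sapiens) for cytotoxicity, with a stated time of 72 h (on this read-out higher numbers stand for lower toxicity in this test and lower numbers for higher toxicity in this test), compound 1 (`CC(C)CCn1nc(-c2ccn(C)c2)c(O)c(C2=NS(=O)(=O)c3cc(NS(C)(=O)=O)ccc3N2)c1=O`) gives > 1000 nM as a limit of the assay and not a number. Compound 2 (`CC(C)CCn1nc(-c2ccccc2)c(O)c(C2=NS(=O)(=O)c3cc(NS(C)(=O)=O)ccc3N2)c1=O`) gives > 1000 nM as a limit too. Compound 2 therefore has no number of its own and stands at the limit of > 1000 nM in this assay, at which 2 of the 2 values shown sit, in the data so far. Compound 3 (`CC(C)CCn1nc(C2CCCC2)c(O)c(C2=NS(=O)(=O)c3cc(NS(C)(=O)=O)ccc3N2)c1=O`) differs from compound 2 by cyclopentyl in place of phenyl on an aromatic carbon and the change is cyclopentyl in place of phenyl on an aromatic carbon. For the measured compounds named here, the one measured step is a step that the two limits leave unreadable from compound 1 to compound 2 and it offers no size to carry over. Going by the values given here, with only that step as a guide, the estimated change is a step that the limit leaves unreadable from compound 2 to compound 3 and no step beyond the scatter is expected in this assay for this swap. Compound 3 is estimated at 2000 nM with an expected range from 1000 nM to 10000 nM and the assay may well report only a limit again.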

Compound 3, half-maximal cytotoxic concentration: > 1000 nM
Compound 3: a limit, no number (the forecaster's own chance of this, stated with the estimate: 85%); the middle value does not contradict the limit.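

Compound 3 gives > 1000 nM in this assay, which is a limit and not a number, so the steps to compound 3 from compound 1 and from compound 2 cannot be read. The compounds shown leave open whether any of these three swaps changes the half-maximal cytotoxic concentration at all.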